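Swapping a carbonyl for a sulfonyl on a ring nitrogen

The compounds below may be only part of what the source reports. "The series", "measured", "known", "first", "only" and "open" are said of these compounds alone.

Measured so far:
Compound 1, `CN(C)c1ccc(C2CC(c3ccc(-n4ccnc4)cc3)=NN2)cc1`: in a functional assay on HCC1806 cells (Homo sapiens) for inhibition, read by sulforhodamine B assay, tested at 10 uM (on this read-out higher numbers stand for more inhibition at the one concentration tested (going by the name of the read-out) and lower numbers for less inhibition), compound 1 gives -20.9%.
Compound 2, `CN1CCN(c2ccc(C3=NN(C(=O)c4ccc(F)cc4)C(c4ccc(N(C)C)cc4)C3)cc2)CC1`: in this assay compound 2 gives 31.8%.

Compound 2 stands highest of the two numbers; compound 1 sits a long way lower, a gap beyond the usual scatter. Among the measured compounds shown here, no step between these two has been worked out, so only their two values can be compared, and they differ in more than one place.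

Compound 3, `CN1CCN(c2ccc(C3=NN(S(=O)(=O)c4ccc(F)cc4)C(c4ccc(N(C)C)cc4)C3)cc2)CC1`, has not been measured. It differs from compound 2 in one place: (4-fluorophenyl)sulfonyl in place of (4-fluorophenyl)carbonyl on an amine nitrogen in a ring. Nothing measured here shows what such a swap does, so the expectation rests on compound 2 alone. The step from compound 2 to compound 3 is expected to be small, a number 1.8 percentage points lower from compound 2 to compound 3 (within the scatter), most likely none beyond the scatter. Compound 3 is therefore estimated at 30%, somewhere between 5% and 55%.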

Compound 3, a percentage reported as inhibition, at one concentration (the size of the read-out at that concentration, not a potency): 92.3%
Compound 3: middle estimate off by 62.3 percentage points, on the low side; measured number above the stated range.
By their numbers in this assay, from the lowest: compound 1; then compound 2; then compound 3.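

In this assay, putting (4-fluorophenyl)sulfonyl in place of (4-fluorophenyl)carbonyl on the amine nitrogen in the five-membered ring gives a number 60.5 percentage points higher from compound 2 to compound 3 (beyond the scatter), with the rest of the molecule unchanged. This nitrogen is therefore a place where the read-out responds strongly to the group that links the 4-fluorophenyl ring, even though that ring itself stays the same, which compound 1 and compound 2, differing in more than one place, could not show. Nothing available explains why the sulfonyl has this effect.

One pair cannot tell whether the rise belongs to sulfonyl groups in general or only to this one; methylsulfonyl or plain phenylsulfonyl on the same nitrogen would test that. Potency also remains open, with only one concentration tested.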